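This account rests on a few compounds, and the source may have more. Where it says the series, first, only, none or still open, it means among the compounds named here.

Two chalcones from the same series have been tested in a functional assay on HeLa cells (Homo sapiens) for inhibition, read by MTT assay, with a stated time of 72 h; on this read-out higher numbers stand for weaker inhibition and lower numbers for stronger inhibition. Compound 1, with structure `COc1cc(O)c(CC=C(C)C)c(O)c1C(=O)/C=C/c1ccc(O)c(O)c1`, gives 38100 nM in this assay. Compound 2, with structure `COc1ccc(/C=C/C(=O)c2c(OC)cc(O)c(CC=C(C)C)c2O)cc1OC`, gives 27700 nM in this assay. Compound 1 thus has the higher of the two numbers, but its gap to compound 2 lies within the usual scatter of such measurements, so the two cannot be ordered.

Compound 3, with structure `COc1cc(O)c(CC=C(C)C)c(O)c1C(=O)/C=C/c1ccc([N+](=O)[O-])cc1`, has not yet been measured. Relative to compound 1 it differs in one place: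

4-nitrophenyl in place of 3,4-dihydroxyphenyl on a double-bonded chain carbon bound to a double-bonded chain carbon

For the measured compounds named here, no pair of measured compounds differs in a single place, so no measured step guides this change. Both known values sit at the weak end of this assay, and the expectation for compound 3 is a step no larger than the scatter, in either direction, written as a 1.4-fold lower number from compound 1 to compound 3 (0.13 log units; within the scatter). Compound 3 is therefore expected to give about 28000 nM in this assay, within a range from 9000 nM to 80000 nM.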

Compound 3, half-maximal inhibitory concentration: 29700 nM
Estimate against measurement, compound 3: 1.1-fold (0.03 log units) below, and the stated range covers the measured number.
By their numbers in this assay, from the lowest: compounds 2, 3 and 1 (each within the scatter of the next).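

For the compounds shown here, the replacement of 3,4-dihydroxyphenyl by 4-nitrophenyl on a double-bonded chain carbon bound to a double-bonded chain carbon provides the first single-place step: in this assay there is a 1.3-fold lower number from compound 1 to compound 3 (0.11 log units; within the scatter). At this position, therefore, a group with 0 hydrogen-bond donors can stand in place of one with 2 hydrogen-bond donors without a change that can be told from the scatter. Nothing measured here bears on why the number stays put.

On these data alone, what a plain phenyl, or a phenyl carrying an amine or a carboxylic acid, would give at this position remains open. As far as these compounds go, it also remains open whether the same replacement would give a step of similar size on the core of compound 2 or in other cell lines.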